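The source may report more compounds than this note shows. Statements on the series, on what has been measured and on what is new or still open speak of the compounds shown alone.

Working notes on the series. Three compounds sharing one core have numbers in an assay on membranes from CHO cells for displacement of a labelled ligand from adenosine receptor A1 (Homo sapiens), read by scintillation counting, with a stated time of 60 min, tested at 1 uM; on this read-out lower numbers stand for less inhibition and higher numbers for more inhibition at the one concentration tested (going by the name of the read-out). Compound 1 `CCNC(=O)C1=C(C)NC(=O)NC1c1ccco1` gives 2%, compound 2 `CC1=C(C(=O)NC(C)C)C(c2ccco2)NC(=O)N1` gives 3%, and compound 3 `CC1=C(C(=O)OC2CCC2)C(c2ccco2)NC(=O)N1` gives 19%. Compound 3 stands highest of the three: the step of a number 17 percentage points higher from compound 1 to compound 3 (beyond the scatter) and the step of a number 16 percentage points higher from compound 2 to compound 3 (beyond the scatter) both exceed the scatter, whereas the step of a number 1 percentage points higher from compound 1 to compound 2 (within the scatter) does not, so compound 1 and compound 2 cannot be ordered against each other.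

Compound 4 `CC1=C(C(=O)OCC2CC2)C(c2ccco2)NC(=O)N1` differs from compound 3 by cyclopropylmethyl in place of cyclobutyl on an oxygen next to a carbonyl group. Among the compounds with values here, both measured steps that exceed the scatter concern the exchange of an amide for an ester, not a change within the ester group, so none of the measured steps bears directly on this one; the two compounds have the same atoms, joined differently. With no guidance, the step of no change at the digits printed from compound 3 to compound 4 (within the scatter) in this assay is expected to remain within the scatter. Compound 4 is therefore estimated at 19% in this assay, with a range from 7% to 33%.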

Compound 4, a percentage reported as inhibition, at one concentration (the size of the read-out at that concentration, not a potency): 29%
Compound 4: middle estimate off by 10 percentage points, on the low side; low and high end bracket the measured number.
By their numbers in this assay, from the lowest: compounds 1 and 2 (each within the scatter of the next); then compounds 3 and 4 (each within the scatter of the next).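

On an oxygen next to a carbonyl group, cyclopropylmethyl in place of cyclobutyl gives a number 10 percentage points higher from compound 3 to compound 4 (within the scatter) in this assay, so this first change within the ester group, which keeps the same atoms joined differently, does not separate the two compounds. A second ester now stands clear of both amides, with a number 26 percentage points higher from compound 2 to compound 4 (beyond the scatter) and a number 27 percentage points higher from compound 1 to compound 4 (beyond the scatter), so the amide-to-ester contrast rests on two esters and none of the four compounds goes against it. Nothing available here bears on the cause of these steps.

Open, on these data alone, is whether a longer chain such as n-hexyl on this oxygen, or a carboxylic acid in place of the ester, would read with the esters or with the amides. Also open, as far as these compounds go, is where cyclopropylmethylamino on the carbonyl carbon would fall, as it would test the ring-bearing group on an amide.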